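From Acetamido to 1,2-Oxazol-4-yl on a Shared Core

The source may hold more compounds than are shown below. What is called first, only, known or untested is meant among the compounds shown, and "the series" means these compounds.

In an in vitro ADME assay on microsomes from liver (Homo sapiens) for metabolic stability, tested at 5 uM (a lower number here means that the compound disappears faster, a higher number that the compound lasts longer), compound 1 `CC(C)CCn1nc(-c2cccs2)c(O)c(C2=NS(=O)(=O)c3ccccc3N2)c1=O` gives 0.2 h, compound 2 `CC(C)CCn1nc(-c2cccs2)c(O)c(C2=NS(=O)(=O)c3cc(NC(=O)C4CC4)ccc3N2)c1=O` gives 0.0833 h, and compound 3 `CC(=O)Nc1ccc2c(c1)S(=O)(=O)N=C(c1c(O)c(-c3cccs3)nn(CCC(C)C)c1=O)N2` gives 0.055 h. Compound 3 shows the lowest of these three numbers: its gap to compound 2 lies within the scatter, while a 3.6-fold lower number from compound 1 to compound 3 (0.56 log units; beyond the scatter) lies beyond it. Compound 4 `CC(C)CCn1nc(-c2cccs2)c(O)c(C2=NS(=O)(=O)c3cc(-c4cnoc4)ccc3N2)c1=O` differs from compound 3 by 1,2-oxazol-4-yl in place of acetamido on an aromatic carbon. Among the measured compounds shown here, no measured step swaps one substituent for another at this position; the steps that bear on it are a 3.6-fold lower number from compound 1 to compound 3 (0.56 log units; beyond the scatter) and a 2.4-fold lower number from compound 1 to compound 2 (0.38 log units; beyond the scatter), each adding a group to a bare aromatic carbon. Removing the acetamido may undo a 3.6-fold lower number from compound 1 to compound 3 (0.56 log units; beyond the scatter) in part, though placing a new ring there has no precedent among these compounds. For compound 4 the expected step is a 1.8-fold higher number from compound 3 to compound 4 (0.26 log units; within the scatter), modest and upward, giving an estimate of 0.1 h within 0.04 h to 0.3 h.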

Compound 4, half-life: 0.5 h
Compound 4: the middle estimate sits 5.0-fold (0.70 log units) below what was measured, outside the stated range (above it).
By their numbers in this assay, from the lowest: compounds 3 and 2 (each within the scatter of the next); then compound 1; then compound 4.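

In this assay a group added to this aromatic carbon need not lower the number: 1,2-oxazol-4-yl gives a 2.5-fold higher number from compound 1 to compound 4 (0.40 log units; beyond the scatter) whereas acetamido and (cyclopropylcarbonyl)amino both gave lower numbers than the bare carbon. With a 9.1-fold higher number from compound 3 to compound 4 (0.96 log units; beyond the scatter) and a 6.0-fold higher number from compound 2 to compound 4 (0.78 log units; beyond the scatter) as well, the outcome at this position depends on which group sits there, not merely on whether one does.

Going by these compounds, whether an amine, a carboxylic acid or a different five-membered aromatic ring would land nearer the 1,2-oxazol-4-yl compound or the amides remains open. Nothing available accounts for the gap between these groups.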